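Cyclopentyl in Place of the Chain on the Nitrogen

This account rests on a few compounds, and the source may have more. Where it says the series, first, only, none or still open, it means among the compounds named here.

Of the compounds shown here, three sharing one core have been measured so far. In a physicochemical assay for acid dissociation, compound 1 `CC(C)CN(C1=NCCN1)c1c(Br)cccc1Br` gives 11, compound 2 `C=C(C)CN(C1=NCCN1)c1c(Br)cccc1Br` gives 10.7 and compound 3 `C/C=C/CN(C1=NCCN1)c1c(Br)cccc1Br` gives 11. Compound 3 stands level with compound 1, the two together being the highest of the three numbers: there is no change at the digits printed from compound 1 to compound 3 (within the scatter), and a number 0.30 log units higher from compound 2 to compound 3 (within the scatter). Between the other pair there is a number 0.30 log units lower from compound 1 to compound 2 (within the scatter). Compound 4 `Brc1cccc(Br)c1N(C1=NCCN1)C1CCCC1` has not yet been measured; it differs from compound 3 in one place: cyclopentyl in place of but-2-en-1-yl on a nitrogen on an aromatic ring. The measured steps that bear on this change are the three swaps of one chain for another on the saturated chain carbon bound to the nitrogen, and none of them moved the read-out beyond the scatter. The present change goes further, bringing a five-membered ring onto the nitrogen itself, but nothing measured reaches that far. The expectation is therefore a step of no change at the digits printed from compound 3 to compound 4 (within the scatter), not beyond the scatter. Compound 4 is estimated at 11, with a range from 10.5 to 11.4.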

Compound 4, acid dissociation constant: 11.2
For compound 4 the middle estimate is 0.20 log units below the measured one; measured number inside the range.
By their numbers in this assay, from the lowest: compounds 2, 1, 3 and 4 (each within the scatter of the next, the first and the last beyond it).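

In this assay, the open chain on a nitrogen on an aromatic ring can give way to a ring with little consequence: the read-out shows a number 0.20 log units higher from compound 3 to compound 4 (within the scatter) and a number 0.20 log units higher from compound 1 to compound 4 (within the scatter), so cyclopentyl cannot be told apart from but-2-en-1-yl or isobutyl here. Only against 2-methylprop-2-en-1-yl does the replacement register, with a number 0.50 log units higher from compound 2 to compound 4 (beyond the scatter), a modest step and the only one in this set beyond the scatter. Nothing available explains that single larger step.

As far as these compounds go, whether a smaller or larger carbon ring, such as cyclopropyl or cyclohexyl, would stay within the scatter of compound 4 remains open. So does the effect on this read-out of a chain carrying an amine or a hydroxyl group at this nitrogen.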